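A few compounds are considered here, and "the series" means these few. Any claim that something is new, unique, unknown or untested is made for them only; others in the source may bear on it.

Measured compounds in an assay on membranes from Cortex for displacement of a labelled ligand from Sigma non-opioid intracellular receptor 1 (Cavia porcellus), read by scintillation counting, with a stated time of 120 min; a higher number here means a weaker inhibitor, a lower number a stronger inhibitor:
Compound 1 `O=C(c1cc2ccccc2o1)N1CCC(NCCSC(c2ccc(F)cc2)c2ccc(F)cc2)CC1` gives 304 nM.
Compound 2 `O=C(c1cc2ccccc2[nH]1)N1CCC(NCCSC(c2ccc(F)cc2)c2ccc(F)cc2)CC1` gives 1130 nM.

Compound 2 stands at the highest of the two numbers in this assay; its nearest neighbour is compound 1, and the step of a 3.7-fold higher number from compound 1 to compound 2 (0.57 log units; beyond the scatter) lies beyond the scatter. Compound 3 `Fc1ccc(C(SCCNC2CCN(Cc3cc4ccccc4o3)CC2)c2ccc(F)cc2)cc1` has not yet been measured in this assay. It differs from compound 2 as follows: (1-benzofuran-2-yl)methyl in place of (1H-indol-2-yl)carbonyl on an amine nitrogen in a ring.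

Among the measured compounds shown here, only one measured step bears on this change, and only in part. The step of a 3.7-fold higher number from compound 1 to compound 2 (0.57 log units; beyond the scatter) shows that the benzofuran ring gave the lower number when it stood on the carbonyl carbon, so returning to benzofuran in compound 3 points towards a lower number. For the measured compounds named here, the other part of the change, the carbonyl giving way to a methylene on the ring nitrogen, has no counterpart among the measured compounds, so its direction and size are unknown from these data. A modest step towards a lower number is therefore expected, a 9.4-fold lower number from compound 2 to compound 3 (0.97 log units; beyond the scatter), with a wide range. Compound 3 is estimated at 120 nM in this assay, between 20 nM and 700 nM.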

Compound 3, inhibition constant: 205 nM
Compound 3: the middle estimate sits 1.7-fold (0.23 log units) below what was measured; measured number inside the range.
By their numbers in this assay, from the lowest: compounds 3 and 1 (each within the scatter of the next); then compound 2.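

In this assay the carbonyl on the amine nitrogen in a ring finally has a direct comparison: with the benzofuran kept, the change to the methylene of (1-benzofuran-2-yl)methyl gives a 1.5-fold lower number from compound 1 to compound 3 (0.17 log units; within the scatter), so this swap on its own shows no measurable effect on the number. The combined change of ring and link, by contrast, gives a 5.5-fold lower number from compound 2 to compound 3 (0.74 log units; beyond the scatter), which leaves the two benzofuran compounds together and compound 2, the only one with the indole, apart from them in all three compounds shown. Nothing measured here explains why the indole compound stands apart, or why the carbonyl and the methylene read alike.

Going by these compounds, what remains open is whether a (1H-indol-2-yl)methyl group on the same ring nitrogen would read like compound 2 or like compound 3, which would show whether the effect of the ring holds with either link. Also open, on these data alone, is how far the flat result for the link extends, for instance to a longer ethylene chain between the benzofuran and the ring nitrogen, or to a plain benzyl group in place of the (1-benzofuran-2-yl)methyl.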